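The compounds below may be only part of what the source reports. "The series", "measured", "known", "first", "only" and "open" are said of these compounds alone.

Compound 1 `CC1Cn2cc([N+](=O)[O-])nc2O1`: > 500000 nM (a limit)
Compound 2 `CC1Cn2c(nc([N+](=O)[O-])c2-c2ccc(Cl)cc2)O1`: > 140000 nM (a limit)
Compound 3 `Cc1ccc(-c2c([N+](=O)[O-])nc3n2CC(C)O3)s1`: > 250000 nM (a limit)

All three were tested in an ADME assay on HepG2 cells (Homo sapiens) for cytotoxicity, read by MTT assay, with a stated time of 24 h; on this read-out lower numbers stand for higher toxicity in this test and higher numbers for lower toxicity in this test. Compound 2 gives only a limit, > 140000 nM, and not a number. Compound 1 and compound 3 likewise give only limits, so compound 2 cannot be ranked against either.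

Compound 4 `CC1Cn2c(nc([N+](=O)[O-])c2-c2ccc(C=O)cc2)O1` differs from compound 2 at one place: formyl in place of chloro on an aromatic carbon.

For the measured compounds named here, only one measured step is available, a step that the two limits leave unreadable from compound 1 to compound 3. It involves a different exchange of groups, and it gives no size to carry over. With so little to go on, no step beyond the usual scatter is expected in this assay, and another limit is the likeliest result. The expected step, a step that the limit leaves unreadable from compound 2 to compound 4, is an estimate that rests on the limit of compound 2 alone. For compound 4 the estimated value is 150000 nM, with an expected range from 60000 nM to 400000 nM.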

Compound 4, half-maximal cytotoxic concentration: > 51000 nM
Compound 4 was reported as a limit (the forecaster's own chance of this, stated with the estimate: 70%); the middle value is on the limit's open side.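

In this assay compound 4 gives only a limit, > 51000 nM. Compound 2 also gives only a limit, > 140000 nM, so no step can be read from compound 2 to compound 4. With only limits shown for all four compounds, it remains open at what concentration any of them becomes toxic to these cells, and whether formyl and chloro differ in this test.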